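Working notes: exchanging the 4-(trifluoromethyl)phenyl group

This account rests on a few compounds, and the source may have more. Where it says the series, first, only, none or still open, it means among the compounds named here.

In a functional assay on SiHa cells (Homo sapiens) for inhibition, read by sulforhodamine B assay (a lower number here means a stronger inhibitor of growth, a higher number a weaker inhibitor of growth), compound 1 (`FC(F)(F)c1ccc(-c2ccc(-c3ccc(-c4nc5ccccc5[nH]4)cc3)cc2)cc1`) gives 100000 nM and compound 2 (`Clc1cccc(-c2ccc(-c3ccc(-c4nc5ccccc5[nH]4)cc3)cc2)c1`) gives the same number, 100000 nM in its case. Going by the values given here, compound 3 (`Oc1cccc2[nH]c(-c3ccc(-c4ccc(-c5ccc(C(F)(F)F)cc5)cc4)cc3)nc12`) gives 3720 nM and so holds the lowest of the three numbers so far.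

The next structure is compound 4 (`COc1ccc(-c2ccc(-c3ccc(-c4nc5c(O)cccc5[nH]4)cc3)cc2)cc1OC`), in which 3,4-dimethoxyphenyl stands in place of 4-(trifluoromethyl)phenyl on an aromatic carbon (3,4-dimethoxyphenyl in place of 4-(trifluoromethyl)phenyl on an aromatic carbon) while the hydroxy group of compound 3 stays. Among the compounds with values here, two measured steps bear on this change. Exchanging the same group for 3-chlorophenyl, in the absence of the hydroxy group, gave no change at the digits printed from compound 1 to compound 2 (within the scatter) in that pair. Adding the hydroxy group gave a 27-fold lower number from compound 1 to compound 3 (1.43 log units; beyond the scatter) and compound 4 keeps that feature. Within the data shown here, no measured compound carries 3,4-dimethoxyphenyl, and no exchange of this group has been measured with the hydroxy group in place, so the range stays wide.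

The expected result in this assay is no step beyond the scatter, with any drift more likely towards a higher number. The estimated step is a 1.2-fold higher number from compound 3 to compound 4 (0.08 log units; within the scatter) on this reasoning. For compound 4 the estimate is 4500 nM as the expected middle, with an expected range from 1300 nM to 20000 nM for repeat measurements.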

Compound 4, concentration for 50% growth inhibition: 1110 nM
For compound 4 the middle estimate is 4.1-fold (0.61 log units) above the measured one; measured number below the stated range.
By their numbers in this assay, from the lowest: compound 4; then compound 3; then compounds 1 and 2 (each within the scatter of the next).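

In this assay, the exchange on this aromatic carbon, para to a large group, can move the number with the hydroxy group in place: 3,4-dimethoxyphenyl in place of 4-(trifluoromethyl)phenyl gives a 3.4-fold lower number from compound 3 to compound 4 (0.53 log units; beyond the scatter). Without the hydroxy group, 3-chlorophenyl in place of 4-(trifluoromethyl)phenyl gave no change at the digits printed from compound 1 to compound 2 (within the scatter), but the two exchanges differ in both the entering group and the rest of the molecule, so the contrast cannot be assigned to either one alone. The groups leaving and entering in the newer step match at 10 heavy atoms and differ in their printed hydrogen-bond acceptors, 0 against 2, yet no accompanying measurement explains the step.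

The compounds shown leave open whether 3,4-dimethoxyphenyl would lower the number in the absence of the hydroxy group, and so whether the two changes add up or depend on each other. They also leave open whether both methoxy groups are needed, and how a single methoxy group, an amine or a carboxylic acid on this phenyl ring would compare.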